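Dropping the aniline methyl of compound 1

The compounds below may be only part of what the source reports. "The series", "measured", "known", "first", "only" and "open" are said of these compounds alone.

Compound 1 `Cc1ccccc1Nc1nc(C)c(C(=O)/C=C/c2ccccc2Cl)s1`: in a functional assay on NCI-H460 cells (Homo sapiens) for cytotoxicity, read by MTT assay (a lower number here means a stronger inhibitor, a higher number a weaker inhibitor), compound 1 gives > 25000 nM, which is a limit of the assay.
Compound 2 `Cc1ccccc1Nc1nc(C)c(C(=O)/C=C/c2ccc(Cl)cc2)s1`: in this assay compound 2 gives > 25000 nM, again only a limit.
Compound 3 `COc1cc(/C=C/C(=O)c2sc(Nc3ccc(Cl)c(Cl)c3)nc2C)cc(OC)c1OC`: in this assay compound 3 gives > 25000 nM, also a limit.

Compound 1 therefore stands at the edge of what this assay can read, and so do the other two values shown. Within the data shown here, the single measured step, a step that the two limits leave unreadable from compound 1 to compound 2, cannot be sized because of the limit of > 25000 nM in this assay, at which 3 of the 3 values shown sit.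

Compound 4 `Cc1nc(Nc2ccccc2)sc1C(=O)/C=C/c1ccccc1Cl` differs from compound 1 by hydrogen in place of methyl on an aromatic carbon. Among the measured compounds shown here, no measured step bears on this change, so the expectation rests only on where compound 1 itself sits. Compound 4 is expected to give about 30000 nM, somewhere from 10000 nM to 100000 nM, and the estimated step that the limit leaves unreadable from compound 1 to compound 4 amounts to no change beyond the scatter. Most likely the assay reports another limit.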

Compound 4, half-maximal inhibitory concentration: > 25000 nM
Compound 4: no number, only a limit (the forecaster's own chance of this, stated with the estimate: 85%); the middle value lies beyond the limit too.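

The change from compound 1 to compound 4 cannot be sized, because both values are limits and not numbers: the limit of > 25000 nM in this assay, at which 4 of the 4 values shown sit.

The compounds shown leave open whether removing this methyl changes cytotoxicity at all, and which changes to the shared core would give a readable value in this assay.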